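The compounds below may be only part of what the source reports. "The series", "measured", "known", "first", "only" and "open" are said of these compounds alone.

Measured so far:
Compound 1, `Cc1nc(-c2ccccc2F)c(C(=O)N2CCN(c3cc(Cl)cc(Cl)c3)CC2)o1`: 0.177 ug/mL
Compound 2, `Cc1nc(-c2ccccc2)c(C(=O)N2CCN(c3ccc(C)c(C)c3)CC2)o1`: 3.52 ug/mL

Both numbers come from a toxicity assay on HUVEC cells (Homo sapiens) for inhibition; on this read-out lower numbers stand for stronger inhibition of growth and higher numbers for weaker inhibition of growth. Compound 2 stands highest of the two numbers shown, so its inhibition of growth is the weaker one; compound 1 gives a lower number, a gap that lies beyond the scatter of this assay.

Compound 3, `Cc1nc(-c2ccccc2)c(C(=O)N2CCN(c3cccc(Cl)c3)CC2)o1`, is the next compound to be tested. It is built from compound 2 by one change: 3-chlorophenyl in place of 3,4-dimethylphenyl on an amine nitrogen in a ring. Compound 1 differs from compound 2 in two places at once, so its number cannot be pinned on any single change, yet the two values taken together show that a ring bearing chlorine atoms went with the lower number.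

The step from compound 2 to compound 3 is therefore expected to go toward a lower number, as a 3.5-fold lower number from compound 2 to compound 3 (0.55 log units; beyond the scatter). Compound 3 is estimated at 1 ug/mL, within a range from 0.3 ug/mL to 3.5 ug/mL.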

Compound 3, concentration for 50% growth inhibition: 0.463 ug/mL
Beside the measured number, compound 3's estimate is 2.2-fold (0.33 log units) above it, and the stated range covers the measured number.
By their numbers in this assay, from the lowest: compound 1; then compound 3; then compound 2.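

In this assay, putting 3-chlorophenyl in place of 3,4-dimethylphenyl on the amine nitrogen in the ring gives a 7.6-fold lower number from compound 2 to compound 3 (0.88 log units; beyond the scatter). This shows that a change at this one position, with the rest of the molecule left as it was, is enough to move the number beyond the scatter; compound 1 could not show this, as it differs from compound 2 in two places at once. Nothing measured here explains why the number falls with this change.

On these data alone, the step swaps two methyl groups for one chlorine, so how much each part contributes stays open until 3-methylphenyl or 4-chlorophenyl is read on the same nitrogen. Also open, as far as these compounds go, is how a ring carrying a methoxy group or an amine would behave at this position.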